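The source may report more compounds than this note shows. Statements on the series, on what has been measured and on what is new or still open speak of the compounds shown alone.

Measured compounds:
- compound 1, `O=C(NCc1ccc(C(=O)N2CCCCc3ccccc32)c(F)c1)Nc1c(F)cccc1F`; in a functional assay on HEK293 cells for agonist activity at Vasopressin V2 receptor (Homo sapiens), read by a luciferase reporter and cAMP accumulation (a lower number here means that less compound is needed, a higher number that more compound is needed for the effect), compound 1 gives 180 nM
- compound 2, `Cc1cc(C(=O)N2CCCCc3ccccc32)ccc1CNC(=O)NCC(=O)OC(C)C`; compound 2 gives 140 nM
- compound 3, `Cc1cc(C(=O)N2CCCCc3ccccc32)ccc1CNC(=O)N1CCC[C@H]1C(=O)OC(C)(C)C`; compound 3 gives 390 nM

Compound 2 carries the lowest number of the three. Against compound 1 the gap is within the scatter, so no order between compounds 1 and 2 can be read; against compound 3 the gap is beyond the scatter.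

Compound 4, `Cc1cc(C(=O)N2CCCCc3ccccc32)ccc1CNC(=O)N1C[C@H](O)C[C@H]1C(=O)N(C)C`, is not yet measured. It differs from compound 2 in one place: 2-(dimethylcarbamoyl)-4-hydroxypyrrolidin-1-yl in place of ((isopropoxycarbonyl)methyl)amino on a carbonyl carbon

Among the measured compounds shown here, one measured step bears on this change: a 2.8-fold higher number from compound 2 to compound 3 (0.44 log units; beyond the scatter). There too a ring built on a pyrrolidine replaced the open chain on the same carbonyl carbon, and the number rose modestly. For the measured compounds named here, compound 4 carries a different substituent on that ring and an added hydroxyl, for which no measured step exists, so the direction of the step rests only on compound 3. A modest rise, of about the size seen with compound 3, is therefore expected: a 2.3-fold higher number from compound 2 to compound 4 (0.36 log units; beyond the scatter). Compound 4 is estimated at 320 nM, with a range from 120 nM to 900 nM.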

Compound 4, half-maximal effective concentration: 2.3 nM
Estimate against measurement, compound 4: 140-fold (2.14 log units) above; measured number outside the range, below it.
By their numbers in this assay, from the lowest: compound 4; then compounds 2 and 1 (each within the scatter of the next); then compound 3.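

In this assay, among the compounds shown here, this carbonyl carbon proves far more sensitive than the earlier compounds indicated, with the change giving a 61-fold lower number from compound 2 to compound 4 (1.78 log units; beyond the scatter). A pyrrolidine ring on this carbon does not by itself fix the direction of the step: two pyrrolidine-bearing compounds are separated by a 170-fold lower number from compound 3 to compound 4 (2.23 log units; beyond the scatter), so the result depends on what the ring carries. Nothing measured here bears on the reason for this gain.

The dimethylcarbamoyl and hydroxyl groups enter together in compound 4, so their separate contributions remain unresolved. Also open, on these data alone, is whether a carboxylic acid or primary carboxamide in place of the dimethylcarbamoyl group, or an amine or methoxy group in place of the hydroxyl, would keep the number near that of compound 4.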